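The source may hold more compounds than are shown below. What is called first, only, known or untested is meant among the compounds shown, and "the series" means these compounds.

Compound 2, with the structure `CCCCN(CCCC)c1nc(C)nc2c1ncn2-c1ccc(C(C)C)cc1Br`, was tested in an in vitro assay on 293-EBNA cells for binding affinity to corticotropin-releasing factor receptor 1 (Homo sapiens) (a higher number here means a weaker inhibitor, a lower number a stronger inhibitor), and gave 6.1 nM. Two other compounds were measured the same way: compound 1, `CCC(COC)Nc1nc(C)nc2c1nnn2-c1c(C)cc(C)cc1C`, which in this assay gave 59.4 nM, and compound 3, `CCCCN(CC)c1nc(C)nc2c1ncn2-c1c(C)cc(C)cc1C`, which gave 25 nM. Among these three, compound 2 has the lowest number; compound 3 is its nearest neighbour and compound 1 the furthest, and both gaps lie beyond the usual scatter of this kind of measurement.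

Compound 4, `CCC(COC)Oc1nc(C)nc2c1ncn2-c1ccc(C(C)C)cc1Br`, keeps the rest of compound 2 and differs in one place: 1-(methoxymethyl)propoxy in place of dibutylamino on an aromatic carbon. Going by the values given here, no measured pair shows this change on its own, so its effect is not known from the data. Compound 1 carries a related chain, but it also differs from compound 2 elsewhere, so its value cannot be tied to that chain alone. The step from compound 2 to compound 4 is expected to be a 4.1-fold higher number from compound 2 to compound 4 (0.61 log units; beyond the scatter), towards a weaker inhibitor and beyond the scatter. Compound 4 is therefore estimated at 25 nM, within a range from 6 nM to 100 nM.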

Compound 4, inhibition constant: 9.7 nM
For compound 4 the middle estimate is 2.6-fold (0.41 log units) above the measured one; the measured number falls inside the stated range.
By their numbers in this assay, from the lowest: compounds 2 and 4 (each within the scatter of the next); then compound 3; then compound 1.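

Replacing dibutylamino with 1-(methoxymethyl)propoxy on this aromatic carbon gives a 1.6-fold higher number from compound 2 to compound 4 (0.20 log units; within the scatter) in this assay, so the two compounds cannot be told apart. Going by these compounds alone, this is the first direct reading of a change at this position: a chain of 7 heavy atoms with 2 oxygen and no nitrogen takes the place of one of 9 heavy atoms with 1 nitrogen, and the result stays within the scatter. No measurement here offers an explanation for this result.

Compound 1 and compound 3 differ from compound 2 in more than one place, so they do not show whether the same outcome would hold with another aromatic ring on the core. As far as these compounds go, it also remains open how a ring-containing amine such as morpholine, or a shorter ether such as methoxy, would read at this position.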